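Bromo in place of methoxy on compound 3

The source may hold more compounds than are shown below. What is called first, only, known or untested is meant among the compounds shown, and "the series" means these compounds.

Values measured in a functional assay on HT-29 cells (Homo sapiens) for antiproliferative activity, read by sulforhodamine B assay, with a stated time of 48 h; a higher number here means a weaker inhibitor, a lower number a stronger inhibitor:
compound 1 `COc1cccc(OS(=O)(=O)c2ccc(N3CCN(C)C3=O)cc2)c1`: 2500 nM
compound 2 `CN1CCN(c2ccc(S(=O)(=O)Oc3ccc(Cl)cc3)cc2)C1=O`: 12000 nM
compound 3 `CCN1CCN(c2ccc(S(=O)(=O)Oc3cccc(OC)c3)cc2)C1=O`: 22000 nM

Compound 3 sits level with compound 2 within the usual scatter, and well above compound 1, as an 8.8-fold higher number from compound 1 to compound 3 (0.94 log units; beyond the scatter) shows. That step swaps a hydrogen for a methyl elsewhere in the molecule. Compound 3 and the unmeasured compound 4 `CCN1CCN(c2ccc(S(=O)(=O)Oc3cccc(Br)c3)cc2)C1=O` share that change, so it says little about the next swap.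

Compound 4 carries bromo in place of methoxy on an aromatic carbon, and bromo in place of methoxy on an aromatic carbon gives the count. Among the measured compounds shown here, no measured compound carries bromo. The closest evidence is a 4.8-fold higher number from compound 1 to compound 2 (0.68 log units; beyond the scatter), where 3-methoxyphenyl also left, but 4-chlorophenyl entered instead of 3-bromophenyl. It is therefore only a loose guide, leaning towards a higher number.

The estimate in this assay is for little movement, an expected 1.3-fold higher number from compound 3 to compound 4 (0.10 log units; within the scatter) in all. For compound 4 the estimated value is 28000 nM, with an expected range of 9000 nM to 80000 nM.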

Compound 4, half-maximal inhibitory concentration: 3800 nM
Compound 4: the middle estimate sits 7.4-fold (0.87 log units) above what was measured, and the stated range ends above it.
By their numbers in this assay, from the lowest: compounds 1 and 4 (each within the scatter of the next); then compounds 2 and 3 (each within the scatter of the next).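

In this assay, bromo in place of methoxy, on the same aromatic carbon, gives a 5.8-fold lower number from compound 3 to compound 4 (0.76 log units; beyond the scatter), so the group held at this place matters in its own right. The earlier change from 3-methoxyphenyl to 4-chlorophenyl, a 4.8-fold higher number from compound 1 to compound 2 (0.68 log units; beyond the scatter), altered both the group and its place on the ring and could not separate the two; here only the group changes, and the number falls rather than rises. Nothing measured for these compounds accounts for this fall.

Going by these compounds, it remains open whether chloro, methyl or an amine at this same place would give a step like that of bromo. Also open, on these data alone, is whether bromo in place of methoxy would give a step of similar size on the core of compound 1.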